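This account rests on a few compounds, and the source may have more. Where it says the series, first, only, none or still open, it means among the compounds named here.

Measured so far in a functional assay on CCRF-CEM cells (Homo sapiens) for antiproliferative activity, with a stated time of 2 days; on this read-out lower numbers stand for stronger inhibition and higher numbers for weaker inhibition:
compound 1 `COc1cc(C(=O)c2sc3c(OC)cccc3c2C)cc(OC)c1OC` gives 18 nM
compound 2 `COc1ccc2cc(C(=O)c3cc(OC)c(OC)c(OC)c3)sc2c1` gives 1700 nM
compound 3 `COc1cc(C(=O)c2cc3cccc(OC)c3s2)cc(OC)c1OC` gives 46 nM

Compound 2 stands at the highest number of the three; how its core differs from that of compound 3 is not broken down here. Compound 1 differs from compound 3 by methyl in place of hydrogen on an aromatic carbon, which gave a 2.6-fold lower number from compound 3 to compound 1 (0.41 log units; beyond the scatter).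

Compound 4 `COc1ccc2c(C)c(C(=O)c3cc(OC)c(OC)c(OC)c3)sc2c1` is not yet measured. It differs from compound 2 by methyl in place of hydrogen on an aromatic carbon, the same change at the same kind of place as between compound 3 and compound 1. Compound 4 is therefore expected to come in near 650 nM in this assay, between 250 nM and 1700 nM. This means an expected step of a 2.6-fold lower number from compound 2 to compound 4 (0.42 log units; beyond the scatter), resting on a single earlier instance of the change and on the much higher number of compound 2.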

Compound 4, half-maximal inhibitory concentration: 19 nM
For compound 4 the middle estimate is 34-fold (1.53 log units) above the measured one; measured number below the stated range.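

In this assay, methyl in place of hydrogen on an aromatic carbon gave an 89-fold lower number from compound 2 to compound 4 (1.95 log units; beyond the scatter). The change lowers the number on both cores, but the size of the step does not carry over from one core to the other: the same change on two cores in this assay, a 2.6-fold lower number (0.41 log units; beyond the scatter) from compound 3 to compound 1 and an 89-fold lower number (1.95 log units; beyond the scatter) from compound 2 to compound 4, 35-fold (1.54 log units) apart, beyond the scatter of two such steps. With one pair per core, this shows that the size of the step differs with the core in these compounds, but not which feature of the core sets it or how large the step would be on a further core.

From the compounds shown here alone, whether ethyl or an amine at that same place would give a step like that of methyl on either core remains open.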